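Notes on the alkyne series: compound 3 to compound 4

The compounds below may be only part of what the source reports. "The series", "measured", "known", "first", "only" and "open" are said of these compounds alone.

In an assay on HEK293 cells for displacement of a labelled ligand from metabotropic glutamate receptor 5 (Homo sapiens), with a stated time of 2 h (on this read-out lower numbers stand for stronger inhibition and higher numbers for weaker inhibition), compound 1 `CN1CCc2nc(C#Cc3ccc(Cl)cc3)ccc2C1=O` gives 6150 nM, compound 2 `CN1CCc2nc(C#Cc3ccccn3)ccc2C1=O` gives 6240 nM, and compound 3 `CN1CCc2nc(C#Cc3cccnc3)ccc2C1=O` gives 27400 nM, the highest number of the three. The steps of a 4.5-fold higher number from compound 1 to compound 3 (0.65 log units; beyond the scatter) and a 4.4-fold higher number from compound 2 to compound 3 (0.64 log units; beyond the scatter) set compound 3 apart from both others beyond the scatter, whereas a 1.0-fold higher number from compound 1 to compound 2 (0.01 log units; within the scatter) stays within it. Compound 4 `O=C1c2ccc(C#Cc3cccnc3)nc2CCN1C1CCCCC1` differs from compound 3 in one place: cyclohexyl in place of methyl on an amide-type nitrogen in a ring. For the measured compounds named here, every measured step concerns the group on the triple-bonded carbon; none touches the amide-type nitrogen, so no measured step bears on this change. For compound 4 in this assay the expectation is therefore no step beyond the scatter, with a wide range to reflect the lack of support: the estimate for compound 4 is 20000 nM (4000 nM to 100000 nM), an expected step of a 1.4-fold lower number from compound 3 to compound 4 (0.14 log units; within the scatter).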

Compound 4, inhibition constant: 15600 nM
For compound 4 the middle estimate is 1.3-fold (0.11 log units) above the measured one; low and high end bracket the measured number.
By their numbers in this assay, from the lowest: compounds 1 and 2 (each within the scatter of the next); then compounds 4 and 3 (each within the scatter of the next).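

For the compounds shown here, at the amide-type nitrogen in a ring, a position no earlier step touched, cyclohexyl in place of methyl gives a 1.8-fold lower number from compound 3 to compound 4 (0.24 log units; within the scatter) in this assay. With pyridin-3-yl on the triple-bonded carbon, this position therefore takes a much larger carbon-only ring without a step beyond the scatter. No measurement at hand gives a reason for this result. Open, on these data alone, is whether the same change reads alike with pyridin-2-yl or 4-chlorophenyl on the triple-bonded carbon. Also open, as far as these compounds go, is whether an amine, a carboxylic acid or a longer chain on this nitrogen would give a step beyond the scatter.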